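The source may report more compounds than this note shows. Statements on the series, on what has been measured and on what is new or still open speak of the compounds shown alone.

Measured compounds:
- compound 1, `CO[C@@H]1O[C@H](CNC(=S)NCCN([C@@H](C(=O)O)C(C)C)S(=O)(=O)c2ccc(-c3ccccc3)cc2)[C@@H](O)[C@H](O)[C@H]1O`: 520 nM
- compound 2, `CO[C@@H]1O[C@H](CN([C@@H](C(=O)O)C(C)C)S(=O)(=O)c2ccc(-c3ccccc3)cc2)[C@@H](O)[C@H](O)[C@H]1NC(C)=O`: 890 nM
- compound 3, `CC(=O)N[C@@H]1[C@@H](OC(C)=O)[C@H](OC(C)=O)[C@@H](COC(C)=O)O[C@H]1N([C@@H](C(=O)O)C(C)C)S(=O)(=O)c1ccc(-c2ccccc2)cc1`: "not determined" (no result reported)

In an assay on isolated protein for inhibition of matrix metalloproteinase-9 (Homo sapiens), read by fluorescence, with stated times of 3 h, 10 s and 15 min (on this read-out lower numbers stand for stronger inhibition and higher numbers for weaker inhibition), compound 1 gives 520 nM, and compound 2 gives 890 nM. Compound 1 has the smaller of the two numbers, but the gap to compound 2 lies within the scatter of repeated measurements, so the two cannot be told apart. For compound 3 no value was reported in this assay.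

Compound 4, `CC(C)[C@H](C(=O)O)N(CCNC(=S)N[C@@H]1O[C@H](CO)[C@@H](O)[C@H](O)[C@H]1O)S(=O)(=O)c1ccc(-c2ccccc2)cc1`, differs from compound 1 in the sugar that hangs off the thiourea: a group of 11 heavy atoms (6 carbon, 5 oxygen; one six-membered non-aromatic ring with 1 hetero atom) in place of a group of 12 heavy atoms (7 carbon, 5 oxygen; one six-membered non-aromatic ring with 1 hetero atom), on an amide-type nitrogen. The sulfonyl valine core and the thiourea link stay unchanged; only the sugar piece and its attachment move. Among the measured compounds shown here, since no step between two measured compounds is known here, there is no measured guide to how large such a change can be. The expectation is that compound 4 stays close to compound 1, with a step of a 1.2-fold higher number from compound 1 to compound 4 (0.06 log units; within the scatter) that falls within the scatter and no clear direction. Compound 4 is therefore estimated at 600 nM, with a range from 250 nM to 1500 nM.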

Compound 4, half-maximal inhibitory concentration: 1120 nM
Compound 4: middle estimate off by 1.9-fold (0.27 log units), on the low side; the measured number falls inside the stated range.
By their numbers in this assay, from the lowest: compounds 1, 2 and 4 (each within the scatter of the next, the first and the last beyond it).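

Among the compounds shown here, this is the first step here between two compounds that differ in one place: in this assay, putting 3,4,5-trihydroxy-6-(hydroxymethyl)oxan-2-yl on the amide-type nitrogen in place of the other sugar group gives a 2.2-fold higher number from compound 1 to compound 4 (0.33 log units; beyond the scatter). The step is modest, but it lies beyond the scatter, so exchanging one sugar group for another at this position can change the reading even with the rest of the molecule held constant. No available measurement explains why the number moves in this direction.

A single step cannot show whether a sugar group is needed here at all, since a plain methyl group or a phenyl ring on the same nitrogen would be the direct test. From the compounds shown here alone, how far other sugar groups on this nitrogen would shift the number also remains open.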